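Hydrazone series: methoxy removal and cytotoxicity read-out

This account rests on a few compounds, and the source may have more. Where it says the series, first, only, none or still open, it means among the compounds named here.

Measured compounds:
Compound 1, `COc1cc(/C=N/NC(=O)OCc2ccccc2)cc(OC)c1O`, gives 69% in a functional assay on cells (Mus musculus) for cytotoxicity, read by MTT assay, with a stated time of 24 h, tested at 10 uM; on this read-out higher numbers stand for a stronger effect at the one concentration tested and lower numbers for a weaker effect.
Compound 2, `COc1cc(/C=N/NC(=O)c2ccncc2)cc(O)c1O`, gives 80% in this assay.
Compound 3, `COc1cc(/C=N/NC(=O)OCc2ccccc2)ccc1O`, gives 73% in this assay.

Compound 1 and compound 3 differ in one place only: hydrogen in place of methoxy on an aromatic carbon. In this assay this gives a number 4 percentage points higher from compound 1 to compound 3 (within the scatter), so the two read-outs are not separable.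

Compound 2 carries a different core; the difference between the two cores of compound 1 and compound 2 is not broken down here. Its number in this assay lies above that of compound 1 by more than the scatter, while the gap to compound 3 lies within the scatter, so no ordering of compound 2 against compound 3 is claimed.

Compound 4, `O=C(N/N=C/c1ccc(O)c(O)c1)c1ccncc1`, has not been measured. It differs from compound 2 by hydrogen in place of methoxy on an aromatic carbon. This is the same kind of change as from compound 1 to compound 3, not the same: around the place in compound 1 the carbon is meta to a methoxy group, whereas in compound 2 it is meta to a hydroxy group.

Going by the values given here, the only measured instance of this kind of change, a number 4 percentage points higher from compound 1 to compound 3 (within the scatter), is within the scatter. On that basis the expected step is a number 1 percentage points higher from compound 2 to compound 4 (within the scatter), essentially flat, resting on compound 2 at 80%. Compound 4 is therefore estimated at 81%, with an expected range from 69% to 92%.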

Compound 4, a percentage reported as activity, at one concentration (the size of the read-out at that concentration, not a potency): 101%
Compound 4: middle estimate off by 20 percentage points, on the low side, and the stated range ends below it.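

Hydrogen in place of methoxy on an aromatic carbon, here ortho to a hydroxy group, gives a number 21 percentage points higher from compound 2 to compound 4 (beyond the scatter) in this assay. The size of this step does not carry over unchanged from one core to the other: the same change on two cores in this assay, a number 4 percentage points higher (within the scatter) from compound 1 to compound 3 and a number 21 percentage points higher (beyond the scatter) from compound 2 to compound 4, 17 percentage points apart, beyond the scatter of two such steps. Going by these compounds alone, the two pairs show only that the step can differ between these cores; they do not show which difference between the core of compound 1 and the core of compound 2 goes with the larger step, and neither step alone gives a reliable figure for the same change on a further core.

The compounds shown leave open how the core of compound 2 responds to other groups at this place, since only methoxy and hydrogen appear there, and an ethoxy group, a fluorine atom or an amine would test whether the larger step is particular to the loss of methoxy. They also leave open how the step looks on the core of compound 1 and the core of compound 2 at other concentrations, as each read-out here comes from one concentration and is not a potency.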